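The compounds below may be only part of what the source reports. "The series", "measured", "known", "first", "only" and "open" are said of these compounds alone.

Three compounds of one series have been measured in a functional assay on cells for agonist activity at C-X-C chemokine receptor type 4 (Homo sapiens), read by fluorescence and calcium flux, with a stated time of 90 s; on this read-out lower numbers stand for an effect already at smaller amounts and higher numbers for an effect only at larger amounts of compound:

compound 1, `c1ccc2c(c1)CN[C@@H](CN(CCCCNCc1ccncc1)[C@H]1CCCc3cccnc31)C2`: > 30000 nM
compound 2, `c1ccc2c(c1)CN[C@@H](CN(CCCCNC1CCOCC1)[C@H]1CCCc3cccnc31)C2`: > 30000 nM
compound 3, `O=S1(=O)CCC(NCCCCN(C[C@H]2Cc3ccccc3CN2)[C@H]2CCCc3cccnc32)CC1`: > 30000 nM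

All three share one core and differ only in the group carried on one amine nitrogen. For compound 1 the value of > 30000 nM is a limit of the assay, not a number. For compound 2 the value of > 30000 nM is likewise a limit. For compound 3 the value of > 30000 nM is also a limit, so compound 3 stands at the edge of what this assay can report, together with the two other compounds. The measured steps a step that the two limits leave unreadable from compound 1 to compound 2, a step that the two limits leave unreadable from compound 1 to compound 3 and a step that the two limits leave unreadable from compound 2 to compound 3 cannot be read in size or direction because of the limit of > 30000 nM in this assay, at which 3 of the 3 values shown sit.

Compound 4, `CC1(C)CCC(NCCCCN(C[C@H]2Cc3ccccc3CN2)[C@H]2CCCc3cccnc32)CC1`, is the next compound, not yet measured. Its difference from compound 3 is 4,4-dimethylcyclohexyl in place of 1,1-dioxothian-4-yl on an amine nitrogen. Among the compounds with values here, no measured step bears on this change in a readable way, since every value so far is a limit. The expectation for compound 4 is therefore that it again reaches only the limit, a step of a number no higher from compound 3 to compound 4 (the limit leaves the size open) that is estimated to be none beyond the scatter. Compound 4 is expected to give 30000 nM, with a range from 10000 nM to 100000 nM.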

Compound 4, half-maximal effective concentration: > 30000 nM
Compound 4: no number, only a limit; the forecaster's own chance of this, stated with the estimate: 75%; the middle value lies on the limit itself.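

Compound 4 gives only a limit and not a number, so its steps to compound 1, compound 2 and compound 3 cannot be read in size or direction, because all four compounds end at the same edge of the assay: the limit of > 30000 nM in this assay, at which 4 of the 4 values shown sit.

The compounds shown leave open whether any group on this amine nitrogen gives a measurable effect.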